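The source may report more compounds than this note shows. Statements on the series, on what has been measured and on what is new or still open speak of the compounds shown alone.

Of the compounds shown here, three sharing one core have been measured in a functional assay on HepG2 cells (Homo sapiens) for cytotoxicity, read by MTT assay, with a stated time of 48 h; a lower number here means a stronger inhibitor, a higher number a weaker inhibitor. Compound 1 (`COc1ccc(/C=C2/S/C(=N/c3ccccc3)N(Cc3ccncc3)C2=O)cc1`) gives 19100 nM, compound 2 (`COc1ccc(/C=C2/S/C(=N/c3ccccc3)N(Cc3ccncc3)C2=O)cc1OC`) gives 28900 nM, and compound 3 (`CCOc1cc(/C=C2/S/C(=N/c3ccccc3)N(Cc3ccncc3)C2=O)ccc1O`) gives 20400 nM. Compound 3 therefore lies within the scatter of both other compounds, and the three cannot be told apart on these numbers.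

Compound 4 (`O=C1/C(=C\c2cccc(O)c2)S/C(=N/c2ccccc2)N1Cc1ccncc1`) has 3-hydroxyphenyl in place of 3-ethoxy-4-hydroxyphenyl on a double-bonded chain carbon bound to a double-bonded ring carbon.

For the measured compounds named here, three measured steps bear on this change, all at that same part of the structure. The data show a 1.5-fold higher number from compound 1 to compound 2 (0.18 log units; within the scatter), then a 1.1-fold higher number from compound 1 to compound 3 (0.03 log units; within the scatter), and finally a 1.4-fold lower number from compound 2 to compound 3 (0.15 log units; within the scatter). All three stay within the scatter, so exchanging these groups has so far left the number in this assay unresolved. Going by the values given here, none of the measured compounds carries 3-hydroxyphenyl itself, so the expectation for compound 4 is an extrapolation and its range is kept wide.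

No step beyond the scatter is expected, and the estimated step is a 1.1-fold higher number from compound 3 to compound 4 (0.03 log units; within the scatter). The estimate for compound 4 is 22000 nM, with an expected range from 11000 nM to 42000 nM.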

Compound 4, half-maximal inhibitory concentration: 17600 nM
For compound 4 the middle estimate is 1.3-fold (0.10 log units) above the measured one; the measured number falls inside the stated range.
By their numbers in this assay, from the lowest: compounds 4, 1, 3 and 2 (each within the scatter of the next).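

In this assay, placing 3-hydroxyphenyl on the double-bonded chain carbon bound to a double-bonded ring carbon gives a 1.2-fold lower number from compound 3 to compound 4 (0.06 log units; within the scatter), a 1.1-fold lower number from compound 1 to compound 4 (0.04 log units; within the scatter) and a 1.6-fold lower number from compound 2 to compound 4 (0.22 log units; within the scatter). For the compounds shown here, compounds 1, 2 and 3 all carry at least one methoxy or ethoxy group on this aromatic ring, whereas compound 4 carries neither, and its group has fewer heavy atoms than the 3-ethoxy-4-hydroxyphenyl it replaces, yet no step to compound 4 leaves the scatter. Nothing measured here explains why these exchanges stay unresolved.

The compounds shown leave open whether any group at this position can move the number beyond the scatter, since the aromatic rings here carry only hydroxy, methoxy or ethoxy groups. On these data alone, how an amine or a carboxylic acid on that ring, or a chain longer than ethoxy, would read in this assay also remains open, as does whether a change elsewhere on the shared core would have a larger effect.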